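Moving the amino group around the aryl urea

A few compounds are considered here, and "the series" means these few. Any claim that something is new, unique, unknown or untested is made for them only; others in the source may bear on it.

This account follows a set of aryl ureas that share the core of compound 1 `Cc1cc(NC(=O)Nc2ccccc2OC(F)(F)F)c2ccccc2n1` and were tested in an ADME assay on BJ cells (Homo sapiens) for cytotoxicity, with a stated time of 72 h; a lower number here means that less compound is needed, a higher number that more compound is needed for the effect. In this assay compound 1 gives only a limit of the assay, > 25000 nM. Compound 2 `Cc1cc(NC(=O)Nc2ccccc2N)c2ccccc2n1` carries amino in place of trifluoromethoxy on an aromatic carbon, and in this assay compound 2 likewise gives only a limit, > 25000 nM. Compound 3 `CSc1ccccc1NC(=O)Nc1cc(C)nc2ccccc12` carries methylsulfanyl in place of trifluoromethoxy on an aromatic carbon, and in this assay compound 3 also gives only a limit, > 25000 nM. Because all three values sit at the limit of > 25000 nM in this assay, at which 3 of the 3 values shown sit, the steps a step that the two limits leave unreadable from compound 1 to compound 2, a step that the two limits leave unreadable from compound 1 to compound 3 and a step that the two limits leave unreadable from compound 2 to compound 3 cannot be read, so compound 2 stands at the limit with nothing to separate it from its two neighbours.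

The step to compound 4 `Cc1cc(NC(=O)Nc2ccc(N)cc2)c2ccccc2n1` is a rearrangement of the same atoms: 4-aminophenyl in place of 2-aminophenyl on an amide-type nitrogen. Of the measured steps, only the two that involve compound 2 bear on it, and both are unreadable; none shows any movement in this assay that could be resolved. The expectation is therefore that compound 4 also gives no readable number and remains at the limit, with a step that the limit leaves unreadable from compound 2 to compound 4 that is expected to be no larger than the scatter. Compound 4 is estimated at 40000 nM, within 15000 nM to 150000 nM.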

Compound 4, half-maximal effective concentration: > 25000 nM
Compound 4: a limit, no number; the forecaster's own chance of this, stated with the estimate: 85%; the middle value is on the limit's open side.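

Compound 4 gives only a limit in this assay, > 25000 nM. No new step can be read from this result, and the change from compound 2 to compound 4 stays without a size: the limit of > 25000 nM in this assay, at which 4 of the 4 values shown sit.

The compounds shown leave open whether moving the amino group, or any other change among them, alters the read-out at all.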